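The compounds below may be only part of what the source reports. "The series", "measured", "known", "first", "only" and "open" are said of these compounds alone.

Measured compounds and their values:

Compound 1 `CNc1nc(NCCCN(C)C)c2sc(-c3ccc(N)cc3)cc2n1` sits at a limit of a physicochemical assay for solubility, at pH 2; a lower number here means a less soluble compound, a higher number a more soluble compound; compound 1 gives > 100 ug/mL.
Compound 2 `CNc1nc(NCCCN(C)C)c2sc(-c3ccc(NS(C)(=O)=O)cc3)cc2n1` also sits at a limit in this assay; compound 2 gives > 100 ug/mL.
Compound 3 `CNc1nc(NCCCN(C)C)c2sc(-c3cccc(C#N)c3)cc2n1` likewise sits at a limit in this assay; compound 3 gives > 100 ug/mL.

All three values are limits and not numbers, so compound 3 stands where every value here stands, at the limit of > 100 ug/mL in this assay, at which 3 of the 3 values shown sit. The unmeasured compound 4 `CNc1nc(NCCCN(C)C)c2sc(-c3ccc(C(C)=O)cc3)cc2n1` differs from compound 3 by 4-acetylphenyl in place of 3-cyanophenyl on an aromatic carbon. Among the measured compounds shown here, two measured steps touch the same aryl group, yet a step that the two limits leave unreadable from compound 1 to compound 3 and a step that the two limits leave unreadable from compound 1 to compound 2 both give no readable size. Accordingly the expected step that the limit leaves unreadable from compound 3 to compound 4 cannot be judged against the scatter. Compound 4 is estimated at 120 ug/mL, within 50 ug/mL to 300 ug/mL.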

Compound 4, solubility: > 100 ug/mL
Compound 4 was reported as a limit; the forecaster's own chance of this, stated with the estimate: 70%; the middle value is on the limit's open side.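

Compound 1, compound 2, compound 3 and compound 4 all sit at one limit, so no step among them can be read: the limit of > 100 ug/mL in this assay, at which 4 of the 4 values shown sit.

How far the solubility of these compounds extends past that limit, and how their aryl groups differ there, stays open in this assay.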